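Lipophilicity notes: methyl to butyl on the shared core

The source may report more compounds than this note shows. Statements on the series, on what has been measured and on what is new or still open speak of the compounds shown alone.

compound 1 `COc1cccc(-c2[nH]c3ccc(OC)cc3c2C2=C(Br)C(=O)NC2=O)c1`: 2.79
compound 2 `COc1cccc(-c2[nH]c3ccc(C)cc3c2C2=C(Br)C(=O)NC2=O)c1`: 3.12

In a physicochemical assay for lipophilicity (a lower number here means a more polar compound, a higher number a more lipophilic compound), compound 2 gives 3.12, the higher of the two numbers. The step of a number 0.33 log units higher from compound 1 to compound 2 (beyond the scatter) lies beyond the scatter. Compound 3 `CCCCc1ccc2[nH]c(-c3cccc(OC)c3)c(C3=C(Br)C(=O)NC3=O)c2c1` differs from compound 2 by propyl in place of hydrogen on a saturated chain carbon bound to an aromatic carbon, read one bond further out as methyl to butyl. Going by the values given here, the single measured step, a number 0.33 log units higher from compound 1 to compound 2 (beyond the scatter), exchanges one small group for another and bears only loosely on this change; no measured step covers lengthening a chain. Still, a rise in this assay is expected for compound 3, a number 1.18 log units higher from compound 2 to compound 3 (beyond the scatter). Compound 3 is estimated at 4.3, range 3.7 to 4.9.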

Compound 3, partition coefficient: 3.81
Compound 3: middle estimate off by 0.49 log units, on the high side; low and high end bracket the measured number.
By their numbers in this assay, from the lowest: compound 1; then compound 2; then compound 3.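

Chain length at this aromatic position now has a measured effect: going from methyl to butyl gives (a number 0.69 log units higher from compound 2 to compound 3 (beyond the scatter)) in this assay. Replacing methoxy with butyl gives a larger change (a number 1.02 log units higher from compound 1 to compound 3 (beyond the scatter)) than the methyl replacement did (a number 0.33 log units higher from compound 1 to compound 2 (beyond the scatter)). No supporting data explain the size of these steps.

As far as these compounds go, whether a chain longer than butyl would extend the rise remains open. Also open, from the compounds shown here alone, is where a branched chain, an amine or a carboxylic acid at this place would fall in this assay relative to compound 3.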